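The compounds below may be only part of what the source reports. "The series", "measured", "known", "first", "only" and "open" are said of these compounds alone.

Measured so far in a functional assay on HepG2 cells (Homo sapiens) for cytotoxicity, with a stated time of 24 h; a lower number here means a stronger inhibitor, a higher number a weaker inhibitor:
- compound 1 `COc1cc(Cl)ccc1C(=O)Nc1ccc(Cl)cc1O` gives 7340 nM
- compound 2 `COc1cc(Cl)ccc1C(=O)Nc1cc(Cl)c(Cl)cc1O` gives 11500 nM

Among the measured compounds shown here, compound 1 lies within the scatter of compound 2, the only other measured compound, so the two cannot be ranked.

The next compound is compound 3 `COc1cc(Cl)ccc1C(=O)Nc1ccc(Br)cc1O`, which keeps the core of compound 1 and changes one group: bromo in place of chloro on an aromatic carbon. This is bromo in place of chloro on an aromatic carbon, meta to a hydroxy group and para to a large group.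

For the measured compounds named here, no measured step makes this exchange. The nearest evidence is a 1.6-fold higher number from compound 1 to compound 2 (0.20 log units; within the scatter), where chloro replaces hydrogen on an aromatic carbon. That step adds a group rather than exchanging one, so it bears on the present change only indirectly. Still, it shows that a single added chloro left the read-out within the scatter, and nothing in the two values points to a larger effect here. No step beyond the scatter is therefore expected in this assay, and the direction is left open.

The estimated step is a 1.1-fold higher number from compound 1 to compound 3 (0.04 log units; within the scatter) (an expectation, not a measurement).

Compound 3 is expected at 8000 nM, with an estimated range from 4000 nM to 16000 nM.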

Compound 3, half-maximal inhibitory concentration: 46600 nM
Estimate against measurement, compound 3: 5.8-fold (0.77 log units) below, and the stated range ends below it.
By their numbers in this assay, from the lowest: compounds 1 and 2 (each within the scatter of the next); then compound 3.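

In this assay, the exchange of chloro for bromo on an aromatic carbon, meta to a hydroxy group and para to a large group, gives a 6.3-fold higher number from compound 1 to compound 3 (0.80 log units; beyond the scatter) in this series. Among the compounds shown here, this is the first step beyond the scatter, so a change of a single heavy atom at this position can move the read-out, whereas the earlier step, a 1.6-fold higher number from compound 1 to compound 2 (0.20 log units; within the scatter) with chloro in place of hydrogen, could not be told from the scatter. Nothing measured here accounts for the size or direction of the exchange at this position.

The compounds shown carry only chloro and bromo at this position, so it remains open whether fluoro, iodo, a methyl group or an amine there would give a number close to that of compound 1 or close to that of compound 3. The effect also rests on one pair, leaving open whether bromo in place of chloro elsewhere on the shared core would give a step of similar size and direction.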